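Trifluoromethyl in place of hydrogen on the phenyl of compound 1

The source may hold more compounds than are shown below. What is called first, only, known or untested is meant among the compounds shown, and "the series" means these compounds.

Compound 1 `Cc1nc(-c2ccccc2)sc1COc1ccc2c(c1)OCC2CC(=O)O` is the reference point of this small set. In a functional assay on CHO cells for agonist activity at Free fatty acid receptor 1 (Homo sapiens), read by FLIPR and calcium flux, tested at 100 nM (a lower number here means a weaker effect, a higher number a stronger effect of the compound at the concentration tested), compound 1 gives 54.8%, the second highest of three numbers. Compound 2 `Cc1ccc(-c2nc(C)c(COc3ccc4c(c3)OCC4CC(=O)O)s2)cc1` gives 54.9%, and the step of a number 0.1 percentage points higher from compound 1 to compound 2 (within the scatter); compound 3 `Cc1nc(-c2ccccc2Cl)sc1COc1ccc2c(c1)OCC2CC(=O)O` gives 12.4%, and the step of a number 42.4 percentage points lower from compound 1 to compound 3 (beyond the scatter). Between the two substituted analogues the step of a number 42.5 percentage points lower from compound 2 to compound 3 (beyond the scatter).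

Compound 4 `Cc1nc(-c2ccc(C(F)(F)F)cc2)sc1COc1ccc2c(c1)OCC2CC(=O)O` differs from compound 1 by trifluoromethyl in place of hydrogen on an aromatic carbon. Within the data shown here, two measured steps bear on this change: the methyl-for-hydrogen step from compound 1 to compound 2 left the read-out unchanged within the scatter, while the chloro-for-hydrogen step from compound 1 to compound 3 was large and downward. The data therefore show that a small group on the phenyl can be tolerated, but also that not every substituent is. With only these two steps, an expected outcome for compound 4 is a modest loss, not beyond what the scatter could hide, estimated as a number 9.8 percentage points lower from compound 1 to compound 4 (within the scatter). Compound 4 is expected to give 45% in this assay, with a range from 15% to 70%.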

Compound 4, a percentage reported as activity, at one concentration (the size of the read-out at that concentration, not a potency): 50.4%
The estimate for compound 4 lay 5.4 percentage points below the measured number; low and high end bracket the measured number.
By their numbers in this assay, from the lowest: compound 3; then compounds 4, 1 and 2 (each within the scatter of the next).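

At the position para to a large group, trifluoromethyl, with its 4 heavy atoms, is carried on the phenyl of compound 1 without a step beyond the scatter in this assay (a number 4.4 percentage points lower from compound 1 to compound 4 (within the scatter)). Trifluoromethyl and methyl also read alike at this place (a number 4.5 percentage points lower from compound 2 to compound 4 (within the scatter)), so the tolerance seen with compound 2 now extends to a second, larger group. Among these compounds, compound 3 remains the one compound that goes against this pattern (a number 38 percentage points higher from compound 3 to compound 4 (beyond the scatter)), which shows that the low number of compound 3 is not shared by every substituted phenyl. Nothing shown gives a reason for any of these steps.

Compound 3 differs from compounds 2 and 4 in both the group and its place on the phenyl, so the compounds shown do not separate the effect of chloro from that of its position, and a 4-chlorophenyl or 2-(trifluoromethyl)phenyl analogue would be needed to tell them apart. They also leave open how an amine, a carboxylic acid or a longer chain would read at the position para to a large group.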